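Swapping an Aromatic Ring for a Saturated One

The source may hold more compounds than are shown below. What is called first, only, known or untested is meant among the compounds shown, and "the series" means these compounds.

Compound 1 `O=C(Nc1nnc(-c2cccc(O)c2O)s1)c1ccccc1`: in a functional assay, with a stated time of 30 min, in the absence of a further agent (on this read-out higher numbers stand for weaker inhibition and lower numbers for stronger inhibition), compound 1 gives 22300 nM
Compound 2 `O=C(Nc1nnc(-c2ccc(O)c(O)c2)s1)c1ccc(Cl)cc1`: compound 2 gives 53000 nM
Compound 3 `O=C(COc1ccccc1)Nc1nnc(-c2cccc(O)c2O)s1`: compound 3 gives 16600 nM

Compound 2 stands highest of the three numbers; its nearest neighbour is compound 1 and its furthest compound 3, and both gaps lie beyond the scatter. Compound 4 `O=C(Nc1nnc(-c2ccc(O)c(O)c2)s1)C1CCCCC1` differs from compound 2 by cyclohexyl in place of 4-chlorophenyl on a carbonyl carbon. For the measured compounds named here, the only measured step at that same place, a 1.3-fold lower number from compound 1 to compound 3 (0.13 log units; within the scatter), lay within the scatter, but it sits on the core of compound 1 rather than that of compound 2 and exchanges other groups. Going by the values given here, no measured step replaces an aromatic ring with a non-aromatic one, so guidance is thin. The change is therefore expected to move the number little, a 1.2-fold lower number from compound 2 to compound 4 (0.07 log units; within the scatter). Compound 4 is expected to give 45000 nM in this assay, estimated between 18000 nM and 110000 nM.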

Compound 4, half-maximal inhibitory concentration: 37300 nM
Compound 4: middle estimate off by 1.2-fold (0.08 log units), on the high side, within the range that was stated.
By their numbers in this assay, from the lowest: compounds 3, 1, 4 and 2 (each within the scatter of the next, the first and the last beyond it).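

In this assay, for the compounds shown here, this is the first measured step that replaces an aromatic ring with a non-aromatic one on this carbonyl carbon: cyclohexyl in place of 4-chlorophenyl gives a 1.4-fold lower number from compound 2 to compound 4 (0.15 log units; within the scatter), with no change beyond the scatter. On the core of compound 2, then, neither the aromatic ring nor the chlorine is needed to hold the number at this level. No measurement at hand explains this result. On these data alone, whether the same exchange behaves alike on the core of compound 1 remains open, as does the effect of an amine or a carboxylic acid at this place.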